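The compounds below may be only part of what the source reports. "The series", "measured", "known", "first", "only" and "open" are said of these compounds alone.

Measured compounds:
- compound 1 `Oc1ccc(-c2cc(-c3ccc(F)cc3)cc(-c3ccc(O)cc3)n2)cc1`: 8680 nM
- compound 2 `Oc1ccc(-c2cc(-c3ccc(OC(F)(F)F)cc3)cc(-c3ccccc3O)n2)cc1`: > 50000 nM

In a functional assay on HeLa cells (Homo sapiens) for inhibition (a lower number here means a stronger inhibitor, a higher number a weaker inhibitor), compound 1 gives 8680 nM. For compound 2 this assay reports only > 50000 nM, which is a limit of the assay and not a number. Compound 2 thus stands at the limit of > 50000 nM in this assay, at which 1 of the 2 values shown sits; of the two measured values, it is the one with no definite figure, and its true potency is not resolved.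

Compound 3 `Oc1ccc(-c2cc(-c3ccc(OC(F)(F)F)cc3)cc(-c3ccc(O)cc3)n2)cc1` is not yet measured. It differs from compound 2 in one place: 4-hydroxyphenyl in place of 2-hydroxyphenyl on an aromatic carbon. After this change compound 3 carries two 4-hydroxyphenyl groups on the shared core, the same pattern seen in compound 1, with the 4-trifluoromethoxyphenyl group of compound 2 retained.

Among the compounds with values here, no step between measured compounds is available. Because compound 1 gives 8680 nM with the same two 4-hydroxyphenyl groups, compound 3 is expected to return a definite number rather than a limit, so the step from compound 2 is expected to run toward stronger inhibition, of a size that cannot be set from the data. The expected step is an at least 4.1-fold lower number from compound 2 to compound 3 (0.61 log units; beyond the scatter). Compound 3 is estimated at 12000 nM, within 4000 nM to 40000 nM.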

Compound 3, half-maximal inhibitory concentration: 16900 nM
The estimate for compound 3 lay 1.4-fold (0.15 log units) below the measured number; the range from low to high includes it.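

In this assay, moving from the 2-hydroxyphenyl to the 4-hydroxyphenyl group on the aromatic carbon next to the ring nitrogen gives an at least 2.9-fold lower number from compound 2 to compound 3 (0.47 log units; beyond the scatter), so this place distinguishes between two groups made of the same atoms, and the hydroxyl's location on the phenyl ring matters here. The size of that step has only a lower bound, as compound 2 is known only as a limit of the assay: the limit of > 50000 nM in this assay, at which 1 of the 3 values shown sits. Within the data shown here, with both 4-hydroxyphenyl groups in place, trifluoromethoxy in place of fluoro gives a 1.9-fold higher number from compound 1 to compound 3 (0.29 log units; within the scatter), so that exchange on the third aryl group is not separated from the usual scatter in this assay, and the two compounds sit together as the only pair here with definite numbers.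

As far as these compounds go, whether the hydroxyl itself is required at this place stays open, as does whether a 4-methoxyphenyl or 4-aminophenyl group there would keep a definite number in this assay. Also open, from the compounds shown here alone, is how the 2-hydroxyphenyl group behaves alongside the fluoro group of compound 1, and whether a longer alkoxy chain in place of trifluoromethoxy would shift the number.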